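Adding One Methyl to Compound 2

The source may report more compounds than this note shows. Statements on the series, on what has been measured and on what is new or still open speak of the compounds shown alone.

Measured so far in a functional assay on MCF7 cells (Homo sapiens) for cytotoxicity, read by MTT assay, with a stated time of 24 h; a higher number here means a weaker inhibitor, a lower number a stronger inhibitor
- compound 1 `C=C[C@@]1(C)[C@H]2OC(=O)C(=C)[C@H]([C@@H]2OC(C)=O)[C@H](OC(=O)C(C)(C)O)[C@@H]1C(=C)C=O` gives 550 nM
- compound 2 `C=C1C(=O)O[C@H]2[C@@H](OC(C)=O)[C@@H]1[C@H](OC(=O)C(C)(C)O)[C@H](C(=C)C=O)[C@@]2(C)[C@@H]1CO1` gives 520 nM

Compound 2 cannot be told apart from compound 1 in this assay and shares the top of this very short table with it. Compound 3 `C=C1C(=O)O[C@H]2[C@@H](OC(C)=O)[C@@H]1[C@H](OC(=O)C(C)(O)CC)[C@H](C(=C)C=O)[C@@]2(C)[C@@H]1CO1` differs from compound 2 by methyl in place of hydrogen on a saturated chain carbon, two bonds along the chain from a carbonyl carbon and an oxygen on a saturated carbon and so carries 1-hydroxy-1-methylpropyl where compound 2 carries 1-hydroxy-1-methylethyl. Going by the values given here, no measured step changes this group. Among the compounds with values here, the only step available, oxiran-2-yl in place of vinyl on a saturated ring carbon, is a 1.1-fold lower number from compound 1 to compound 2 (0.02 log units; within the scatter) and offers just weak, indirect guidance. Compound 2 at 520 nM is therefore the natural starting point. The expected change is a 1.0-fold lower number from compound 2 to compound 3 (0.02 log units; within the scatter) and no shift beyond the scatter is expected in either direction. For compound 3 the estimated value is 500 nM with an expected range from 220 nM to 1100 nM in this assay as the read-out.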

Compound 3, half-maximal inhibitory concentration: 510 nM
Beside the measured number, compound 3's estimate is 1.0-fold (0.01 log units) below it; the range from low to high includes it.
By their numbers in this assay, from the lowest: compounds 3, 2 and 1 (each within the scatter of the next).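

In this assay, the one step shown that touches this group, from 1-hydroxy-1-methylethyl to 1-hydroxy-1-methylpropyl, gives a 1.0-fold lower number from compound 2 to compound 3 (0.01 log units; within the scatter). On this saturated chain carbon, two bonds along the chain from a carbonyl carbon and an oxygen on a saturated carbon, methyl and hydrogen therefore cannot be told apart in this read-out, so the earlier comparison of oxiran-2-yl and vinyl now has a companion result at a second place on the molecule. No measurement here offers an explanation for this result.

On these data alone, a single added methyl is a small probe, so it remains open whether a longer chain, such as butyl, or a phenyl ring would also leave the number within the scatter. As far as these compounds go, the hydroxyl is also common to all three compounds, so what an amine or a carboxylic acid would do in its place is unknown.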